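Chlorine Enters the Shared Core of Compound 2

The source may hold more compounds than are shown below. What is called first, only, known or untested is meant among the compounds shown, and "the series" means these compounds.

Compound 1, `CCn1c(CNc2ccccc2)nnc1SCc1nc2cc(C(=O)C(C)C)ccc2o1`, gives 600 nM in an assay on isolated protein for inhibition of long-chain fatty acid transport protein 1 (Homo sapiens); a higher number here means a weaker inhibitor, a lower number a stronger inhibitor.
Compound 2, `CC/C(=N/O)c1ccc2oc(CSc3nnc(CNc4ccccc4)n3CC)nc2c1`, gives 260 nM in this assay.

Within the data shown here, compound 2 holds the lowest of the two numbers measured; the only other compound, compound 1, lies one step away, and that step is a 2.3-fold lower number from compound 1 to compound 2 (0.36 log units; beyond the scatter). The change now considered is one chlorine atom in place of a group of 5 heavy atoms (3 carbon, 1 nitrogen, 1 oxygen; no ring), on an aromatic carbon, which turns compound 2 into compound 3, `CCn1c(CNc2ccccc2)nnc1SCc1nc2cc(Cl)ccc2o1`. Among the measured compounds shown here, only one measured step bears on it: a 2.3-fold lower number from compound 1 to compound 2 (0.36 log units; beyond the scatter), which also took place on an aromatic carbon of the shared core but exchanged one group for another of equal size, so it lowered the number modestly. For the measured compounds named here, no measured step removes a whole group of that kind in favour of a single chlorine, so the direction here is open. A modest move either way is plausible. Compound 3 is therefore expected to give 500 nM in this assay, with a range from 150 nM to 1600 nM. The expected step is a 1.9-fold higher number from compound 2 to compound 3 (0.28 log units; within the scatter).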

Compound 3, half-maximal inhibitory concentration: > 1000 nM
Compound 3 gave a limit, no number (the forecaster's own chance of this, stated with the estimate: 5%); at least 2.0-fold (0.30 log units) between middle value and limit.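

Compound 3 gives only a limit and not a number: the limit of > 1000 nM in this assay, at which 1 of the 3 values shown sits. Even so, putting one chloro on this aromatic carbon, in place of the group of 5 heavy atoms in compound 2 with its hydrogen-bond donor and acceptors, gives an at least 3.8-fold higher number from compound 2 to compound 3 (0.58 log units; beyond the scatter), so this position is not indifferent to what it carries. The comparison with the isopropylcarbonyl group is less firm, since chloro in its place gives an at least 1.6-fold higher number from compound 1 to compound 3 (0.22 log units; that floor lies within the scatter), which does not by itself separate the two groups.

From the compounds shown here alone, how far the true value of compound 3 lies beyond its limit stays unknown, so both steps have only a floor. Going by these compounds, it also remains open whether an amine, a carboxylic acid or a longer chain on this aromatic carbon would give a lower number.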